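A Methoxyphenyl Swap on a Weak Triazole Series

The source may report more compounds than this note shows. Statements on the series, on what has been measured and on what is new or still open speak of the compounds shown alone.

Compound 1 `O=C1O/C(=C\Cn2cc(-c3cc(F)cc(F)c3)nn2)C(OCc2ccccc2)=C1OCc1ccccc1` carries a 3,5-difluorophenyl group on a five-membered aromatic ring with three nitrogens. In a functional assay on HCT-116 cells (Homo sapiens) for antiproliferative activity, read by MTT assay, with a stated time of 72 h (a lower number here means a stronger inhibitor, a higher number a weaker inhibitor), compound 1 gives only a limit, > 100000 nM, so no number is known for it. Two related compounds have numbers: compound 2 `CCCCCCCCCCc1cn(C[C@H](O)[C@H]2OC(=O)C(OCc3ccccc3)=C2OCc2ccccc2)nn1` gives 28800 nM in this assay, and compound 3 `CC(C)(C)c1cn(C[C@H](O)[C@H]2OC(=O)C(OCc3ccccc3)=C2OCc2ccccc2)nn1` gives 28300 nM. Within the data shown here, the one measured step, a 1.0-fold lower number from compound 2 to compound 3 (0.01 log units; within the scatter), concerns an alkyl group, not an aromatic one, and it lies within the scatter, so it bears only loosely on the present change.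

Compound 4 `COc1ccccc1-c1cn(C/C=C2\OC(=O)C(OCc3ccccc3)=C2OCc2ccccc2)nn1` differs from compound 1 as follows: 2-methoxyphenyl in place of 3,5-difluorophenyl on an aromatic carbon. Among the measured compounds shown here, no measured step addresses such an aryl swap, and compound 1 itself sits at the limit (the limit of > 100000 nM in this assay, at which 1 of the 3 values shown sits). The expectation is therefore no step beyond the scatter, with compound 4 most likely also reported only as a limit. Compound 4 is expected to sit at about 100000 nM, within 30000 nM to 300000 nM. That expectation means an estimated step of a number no higher from compound 1 to compound 4 (the limit leaves the size open).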

Compound 4, half-maximal inhibitory concentration: > 100000 nM
Compound 4: no number, only a limit; the forecaster's own chance of this, stated with the estimate: 70%; the middle value sits exactly at the limit.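

Compound 1 and compound 4 each give only a limit in this assay, so no step between them can be read: the limit of > 100000 nM in this assay, at which 2 of the 4 values shown sit.

The compounds shown leave open whether 2-methoxyphenyl and 3,5-difluorophenyl differ at all in their effect on these cells.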